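A few compounds are considered here, and "the series" means these few. Any claim that something is new, unique, unknown or untested is made for them only; others in the source may bear on it.

Compound 1 `O=C(CCCCC(S)CCS)Nc1ccccc1` carries a phenyl on the amide-type nitrogen; in a functional assay on Bel-7402 cells (Homo sapiens) for inhibition, read by MTT assay, with a stated time of 24 h, tested at 100 ug/mL (a lower number here means less inhibition of growth, a higher number more inhibition of growth at the concentration tested), compound 1 gives 7.67%. Compound 2 `O=C(CCCCC(S)CCS)Nc1cccc(Cl)c1` differs from it by chloro in place of hydrogen on an aromatic carbon, and in this assay compound 2 gives 16.1%, so that the step is a number 8.4 percentage points higher from compound 1 to compound 2 (within the scatter). Compound 3 `O=C(CCCCC(S)CCS)Nc1ccccn1` differs from compound 1 by pyridin-2-yl in place of phenyl on an amide-type nitrogen; in this assay compound 3 gives 3.62%, and the step is a number 4.1 percentage points lower from compound 1 to compound 3 (within the scatter). Compound 4 `O=C(CCCCC(S)CCS)Nc1ccc(Cl)cn1` is not yet measured and differs from compound 3 by chloro in place of hydrogen on an aromatic carbon. This is the same kind of change as that between compound 1 and compound 2, but here the place is on a six-membered aromatic ring with 1 nitrogen, two atoms from the ring nitrogen and para to a large group, whereas there it was on a ring of carbon only, meta to a large group. Because a number 8.4 percentage points higher from compound 1 to compound 2 (within the scatter) stayed within the scatter, the estimated step is a number 7.4 percentage points higher from compound 3 to compound 4 (within the scatter). Compound 4 is therefore expected to give 11%, between 3% and 22%.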

Compound 4, percent growth inhibition at one concentration: 50.7%
The estimate for compound 4 lay 39.7 percentage points below the measured number; measured number outside the range, above it.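

In this assay, chloro in place of hydrogen on an aromatic carbon gave a number 47.1 percentage points higher from compound 3 to compound 4 (beyond the scatter), and this step did not match the one seen on the core of compound 1: the same change on two cores in this assay, a number 8.4 percentage points higher (within the scatter) from compound 1 to compound 2 and a number 47.1 percentage points higher (beyond the scatter) from compound 3 to compound 4, 38.7 percentage points apart, beyond the scatter of two such steps The size of this change on one core was therefore no guide to its size on the other in this series. This rests on a single pair of steps, however, and the chloro also sits at a different place in each pair, so the data do not separate the effect of the ring nitrogen from that of the chloro's place.

On these data alone, it remains open what chloro para to a large group would do on the phenyl ring of compound 1. Also open, as far as these compounds go, is whether a methoxy or an amine at the place of the chloro in compound 4 would give a step of like size.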